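This account rests on a few compounds, and the source may have more. Where it says the series, first, only, none or still open, it means among the compounds named here.

Working notes on the series.

Three compounds have been run in a functional assay on MCF7 cells (Homo sapiens) for antiproliferative activity, read by luminescence, with a stated time of 24 h (a higher number here means a weaker inhibitor, a lower number a stronger inhibitor), so far, all built on the same chromane-type core bearing a thiazolidinedione-substituted phenoxymethyl arm. Compound 1 `Cc1c(C)c2c(c(C)c1OC(=O)CCCC[C@@H]1SC[C@@H]3NC(=O)N[C@@H]31)CCC(C)(COc1ccc(CC3SC(=O)NC3=O)cc1)O2` gives 15900 nM in this assay. Compound 2 `Cc1c(C)c2c(c(C)c1OC(=O)CCCC[C@@H]1SC[C@@H]3NC(=O)N[C@@H]31)CCC(C)(COc1ccc(/C=C3\SC(=O)NC3=O)cc1)O2` gives 11200 nM in this assay. The two differ in one place, described as a group of 8 heavy atoms (4 carbon, 1 nitrogen, 2 oxygen, 1 sulfur; one five-membered non-aromatic ring with 2 hetero atoms) in place of a group of 8 heavy atoms (4 carbon, 1 nitrogen, 2 oxygen, 1 sulfur; one five-membered non-aromatic ring with 2 hetero atoms), on an aromatic carbon, and the step is a 1.4-fold higher number from compound 2 to compound 1 (0.15 log units; within the scatter), so the two numbers cannot be told apart.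

Compound 3 `Cc1c(C)c2c(c(C)c1OC(=O)OC(C)(C)C)CCC(C)(COc1ccc(/C=C3\SC(=O)NC3=O)cc1)O2` carries a different ester on the core phenol and gives 7700 nM in this assay. The difference between the core of compound 3 and the core of compound 2 is not broken down here. Compound 3 and compound 2 lie within the scatter of each other; compound 3 and compound 1 lie beyond it.

Compound 4 `Cc1c(C)c2c(c(C)c1OC(=O)OC(C)(C)C)CCC(C)(COc1ccc(CC3SC(=O)NC3=O)cc1)O2` has not yet been measured in this assay. It differs from compound 3 by a group of 8 heavy atoms (4 carbon, 1 nitrogen, 2 oxygen, 1 sulfur; one five-membered non-aromatic ring with 2 hetero atoms) in place of a group of 8 heavy atoms (4 carbon, 1 nitrogen, 2 oxygen, 1 sulfur; one five-membered non-aromatic ring with 2 hetero atoms), on an aromatic carbon, the same kind of change as from compound 2 to compound 1, and the two place descriptions read the same word for word, so it is the same change on the same position.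

Because the earlier occurrence gave a 1.4-fold higher number from compound 2 to compound 1 (0.15 log units; within the scatter), the step from compound 3 to compound 4 is expected to be of similar size, estimated as a 1.4-fold higher number from compound 3 to compound 4 (0.15 log units; within the scatter). For compound 4 the value in this assay is estimated at 10800 nM, expected to fall between 5500 nM and 21000 nM.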

Compound 4, half-maximal inhibitory concentration: 11200 nM
For compound 4 the middle estimate is 1.0-fold (0.02 log units) below the measured one; measured number inside the range.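

In this assay, bringing in the (2,4-dioxo-1,3-thiazolidin-5-yl)methyl group on the core of compound 3 gives a 1.5-fold higher number from compound 3 to compound 4 (0.16 log units; within the scatter), and this step does not differ from the one seen on the core of compound 2: the same change on two cores in this assay, a 1.4-fold higher number (0.15 log units; within the scatter) from compound 2 to compound 1 and a 1.5-fold higher number (0.16 log units; within the scatter) from compound 3 to compound 4, 1.0-fold (0.01 log units) apart, within the scatter of two such steps

Within the data shown here, on these two cores, then, the change carries over with a step of the same size, and a different ester on the core phenol leaves no mark on that step that can be read here. Among these compounds, this does not show that the change itself alters the number, since each step lies within the scatter and neither compound 3 and compound 4 nor compound 2 and compound 1 can be told apart, so the agreement is between two steps too small to read, on only two cores, and gives no general rule for the series.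

The compounds shown leave open whether the step would hold if the ester on the core phenol gave way to a free hydroxyl, a carboxylic acid or an amine, or if the phenoxymethyl arm carried a longer chain. They also leave open whether a core carrying any of these groups would give a step large enough to stand clear of the scatter.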